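A few compounds are considered here, and "the series" means these few. Any claim that something is new, unique, unknown or untested is made for them only; others in the source may bear on it.

Compound 3 `Cc1cc(C)cc(S(=O)(=O)c2c(C(=O)NCC(=O)NCc3ccccc3F)[nH]c3ccc(Cl)cc23)c1` was examined in an ADME assay on MT4 cells (Homo sapiens) for cytotoxicity, read by MTT assay; on this read-out lower numbers stand for higher toxicity in this test and higher numbers for lower toxicity in this test. For compound 3 the result in this assay is a limit of the assay, > 47300 nM, and not a number. Two companions frame it. Compound 1 `Cc1cc(C)cc(S(=O)(=O)c2c(C(=O)NCC(=O)NCc3ccncc3)[nH]c3ccc(Cl)cc23)c1` also reaches only a limit in this assay, > 48900 nM. Compound 2 `Cc1cc(C)cc(S(=O)(=O)c2c(C(=O)NCc3ccc4nc(N)[nH]c4c3)[nH]c3ccc(Cl)cc23)c1` gives a measured number in this assay, 5890 nM. Of the measured steps, an at least 8.0-fold higher number from compound 2 to compound 3 (0.90 log units; beyond the scatter) and a step that the two limits leave unreadable from compound 1 to compound 3 both lead to compound 3, but each ends at a limit, and neither concerns the alteration now in view. Compound 4 `Cc1cc(C)cc(S(=O)(=O)c2c(C(=O)NCC(=O)NC(C)c3ccccc3F)[nH]c3ccc(Cl)cc23)c1` differs from compound 3 only by methyl in place of hydrogen on a saturated chain carbon bound to an amide-type nitrogen and an aromatic carbon. Among the compounds with values here, no measured step bears on this change, so the expectation rests on compound 3 alone and on the small size of the alteration. The step of a number no higher from compound 3 to compound 4 (the limit leaves the size open) is therefore expected to stay within the scatter, with no direction favoured. Compound 4 is estimated at 47300 nM, between 20000 nM and 100000 nM, and most probably the assay will again report only a limit.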

Compound 4, half-maximal cytotoxic concentration: 23000 nM
For compound 4 the middle estimate is 2.1-fold (0.31 log units) above the measured one; low and high end bracket the measured number.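

In this assay, methyl in place of hydrogen on this saturated chain carbon is the first change shown to bring a compound of this amide type off the limit, with an at least 2.0-fold lower number from compound 3 to compound 4 (0.31 log units; beyond the scatter). The number does not fall as far as with the 2-amino-1H-benzimidazol-6-yl group, as a 3.9-fold higher number from compound 2 to compound 4 (0.59 log units; beyond the scatter) shows, and replacing (pyridin-4-yl)methyl with 1-(2-fluorophenyl)ethyl gives an at least 2.1-fold lower number from compound 1 to compound 4 (0.32 log units; beyond the scatter). Compound 3 stands at a limit of the assay, so the first step gives only a minimum size: the limit of > 47300 nM in this assay, at which 1 of the 4 values shown sits.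

Going by these compounds, whether a larger group on the same carbon, such as ethyl or isopropyl, would lower the number further remains open. So does whether methyl at this place would have a similar effect on the compound carrying pyridin-4-yl rather than 2-fluorophenyl.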